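The compounds below may be only part of what the source reports. "The series", "measured", "known", "first", "only" and "open" are said of these compounds alone.

Measured compounds:
compound 1 `Nc1cc(N)c2nc(-c3ccccc3)c(NCc3ccc(Cl)c(Cl)c3)nc2c1`: 30900 nM
compound 2 `COc1cc(CNc2nc3cc(N)cc(N)c3nc2-c2ccccc2)cc(OC)c1OC`: 15500 nM
compound 3 `CCOC(=O)[C@H](CCC(=O)O)NC(=O)c1ccc(CNc2nc3cc(N)cc(N)c3nc2-c2ccccc2)cc1`: < 100000 nM

The three compounds were tested in a functional assay on UACC-62 cells (Homo sapiens) for inhibition, read by sulforhodamine B assay, with a stated time of 48 h; a lower number here means a stronger inhibitor of growth, a higher number a weaker inhibitor of growth. Compound 1 gives 30900 nM in this assay, and compound 2 gives 15500 nM; the gap between these two values lies within the usual scatter, so neither can be placed ahead of the other. For compound 3 this assay reports only a limit, < 100000 nM, and not a number. Within the data shown here, compound 1 therefore stands with the only other compound that has a numerical value, with nothing to separate them.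

The unmeasured compound 4 `Nc1cc(N)c2nc(-c3ccccc3)c(NCc3ccc(F)cc3)nc2c1` differs from compound 1 in one place: 4-fluorophenyl in place of 3,4-dichlorophenyl on a saturated chain carbon bound to a nitrogen on an aromatic ring. Among the measured compounds shown here, no step between measured compounds covers a change of this kind, so there is no measured guide for its size. On the evidence of compounds 1 and 2, whose values sit close together despite quite different benzyl substituents, the step from compound 1 to compound 4 in this assay is expected to be no larger than the scatter, as a 1.1-fold higher number from compound 1 to compound 4 (0.05 log units; within the scatter). Compound 4 is estimated at 35000 nM, with a range from 12000 nM to 100000 nM.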

Compound 4, concentration for total growth inhibition: 29500 nM
Estimate against measurement, compound 4: 1.2-fold (0.07 log units) above; the measured number falls inside the stated range.
By their numbers in this assay, from the lowest: compounds 2, 4 and 1 (each within the scatter of the next).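

Among these compounds, this is the only step read at this position, on a saturated chain carbon bound to a nitrogen on an aromatic ring, with the rest of the core of compound 1 held fixed: in this assay, 4-fluorophenyl in place of 3,4-dichlorophenyl gives a 1.0-fold lower number from compound 1 to compound 4 (0.02 log units; within the scatter). Both chlorine atoms leave and one fluorine enters, and in this one pair the read-out does not separate the two halogen-bearing rings. Compound 3 still stands only as a limit and supplies no step: the limit of < 100000 nM in this assay, at which 1 of the 4 values shown sits.

Among the compounds shown here, whether any group at this position can move the number beyond the scatter stays open, since this single pair compares only two halogen-bearing phenyl rings. A phenyl ring carrying a nitrile or a dimethylamino group, or a longer chain on the nitrogen, would be needed to answer that.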